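Pyrrolidinyl for Diethylamino on a Second Quinazoline Core

The source may report more compounds than this note shows. Statements on the series, on what has been measured and on what is new or still open speak of the compounds shown alone.

Measured compounds:
compound 1, `CCN(CC)C/C=C/C(=O)Nc1cc2c(N3CCc4ccccc43)ncnc2cc1O[C@@H]1CCOC1`, 4980 nM
compound 2, `O=C(/C=C/CN1CCCC1)Nc1cc2c(N3CCc4ccccc43)ncnc2cc1O[C@@H]1CCOC1`, 2310 nM
compound 3, `CCN(CC)C/C=C/C(=O)Nc1cc2c(N3CCCc4ccccc43)ncnc2cc1OC`, 5310 nM

In a functional assay on MCF7 cells (Homo sapiens) for antiproliferative activity, read by MTT assay, with a stated time of 72 h (a higher number here means a weaker inhibitor, a lower number a stronger inhibitor), compound 1 gives 4980 nM, and compound 2 gives 2310 nM. The change between them is pyrrolidin-1-yl in place of diethylamino on a saturated chain carbon bound to a double-bonded chain carbon, and it gave a 2.2-fold lower number from compound 1 to compound 2 (0.33 log units; beyond the scatter). Compound 3 gives 5310 nM; the difference between the core of compound 3 and the core of compound 1 is not broken down here. Compound 4, `COc1cc2ncnc(N3CCCc4ccccc43)c2cc1NC(=O)/C=C/CN1CCCC1`, is not yet measured; it differs from compound 3 by pyrrolidin-1-yl in place of diethylamino on a saturated chain carbon bound to a double-bonded chain carbon, the same change as that from compound 1 to compound 2. Because that earlier change gave a 2.2-fold lower number from compound 1 to compound 2 (0.33 log units; beyond the scatter), a step of about the same size, a 2.2-fold lower number from compound 3 to compound 4 (0.34 log units; beyond the scatter), is expected in this assay. This rests on one pair only, so the band is kept wide. Compound 4 is estimated at 2400 nM, between 1200 nM and 5000 nM.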

Compound 4, half-maximal inhibitory concentration: 3190 nM
Compound 4: the middle estimate sits 1.3-fold (0.12 log units) below what was measured; low and high end bracket the measured number.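

In this assay, pyrrolidin-1-yl in place of diethylamino gave a 1.7-fold lower number from compound 3 to compound 4 (0.22 log units; within the scatter), so on the core of compound 3 this step alone cannot be told from repeat-measurement noise. Set beside the earlier step, the change carried to the second core with no distinguishable difference in size: the same change on two cores in this assay, a 2.2-fold lower number (0.33 log units; beyond the scatter) from compound 1 to compound 2 and a 1.7-fold lower number (0.22 log units; within the scatter) from compound 3 to compound 4, 1.3-fold (0.11 log units) apart, within the scatter of two such steps. These two pairs, from a single assay, agree with each other, but they do not show that the step holds on other cores in the series or establish it firmly on the core of compound 3.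

The compounds shown leave open whether piperidin-1-yl or morpholin-4-yl on the same saturated chain carbon would behave alike. They also leave open whether dimethylamino would do so on either core.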